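Swapping Chlorine for Fluorine on a Benzyl Group

The source may report more compounds than this note shows. Statements on the series, on what has been measured and on what is new or still open speak of the compounds shown alone.

Compound 1 `OC[C@H]1O[C@@H](n2cnc3c(NCc4ccccc4Cl)ncnc32)[C@H](O)[C@@H]1O` and compound 2 `OC[C@H]1O[C@@H](n2cnc3c(NCc4ccc(Cl)c(Cl)c4)ncnc32)[C@H](O)[C@@H]1O` share one core and differ only in the benzyl group. In a functional assay on CCRF-CEM cells (Homo sapiens) for antiproliferative activity, with a stated time of 72 h (on this read-out higher numbers stand for weaker inhibition and lower numbers for stronger inhibition), compound 1 gives 14500 nM, while compound 2 gives 3800 nM, the lowest of the two numbers, separated by a 3.8-fold lower number from compound 1 to compound 2 (0.58 log units; beyond the scatter). Compound 3 `OC[C@H]1O[C@@H](n2cnc3c(NCc4ccc(F)c(Cl)c4)ncnc32)[C@H](O)[C@@H]1O` differs from compound 2 by fluoro in place of chloro on an aromatic carbon. Within the data shown here, the single measured step rearranges chloro groups and says little about exchanging one halogen for another, so only a small step, if any, is expected. Compound 3 is expected to give an estimated 5500 nM, between 2500 nM and 12000 nM, an expected step of a 1.4-fold higher number from compound 2 to compound 3 (0.16 log units; within the scatter).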

Compound 3, half-maximal inhibitory concentration: 3400 nM
For compound 3 the middle estimate is 1.6-fold (0.21 log units) above the measured one, within the range that was stated.
By their numbers in this assay, from the lowest: compounds 3 and 2 (each within the scatter of the next); then compound 1.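

In this assay, fluoro can take the place of chloro para to a large group with only a 1.1-fold lower number from compound 2 to compound 3 (0.05 log units; within the scatter), so at this position the two halogens cannot be told apart. The 3-chloro-4-fluorophenyl group in place of 2-chlorophenyl gives a 4.3-fold lower number from compound 1 to compound 3 (0.63 log units; beyond the scatter), a step beyond the scatter and a modest one. No evidence is available to explain either step. From the compounds shown here alone, whether a non-halogen group at this position, such as methoxy or an amine, would give a similar number remains open, as does the effect of fluoro in place of the other chloro.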